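A few compounds are considered here, and "the series" means these few. Any claim that something is new, unique, unknown or untested is made for them only; others in the source may bear on it.

Of the compounds shown here, three built on a shared two-ring core have been tested in an ADME assay on the whole organism for inhibition, with Triticum aestivum as the target, with a stated time of 5 days; on this read-out higher numbers stand for weaker inhibition and lower numbers for stronger inhibition. Compound 1 `CCCC1Oc2ccc(Cl)cc2N(O)C1=O` gives 470000 nM in this assay. Compound 2 `O=C1C(c2ccccc2)Oc2ccc(Cl)cc2N1O` gives 690000 nM in this assay. Compound 3 `O=C1C(c2ccccc2)Oc2c(Cl)cccc2N1O` gives 263000 nM in this assay; its gap to compound 1 falls within the usual scatter of repeated measurements, while its gap to compound 2 lies beyond that scatter. Compound 2 and compound 3 consist of the same atoms joined differently, and the difference between the two cores is not broken down here.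

One structural change occurs twice in this set. Between compound 2 and compound 1 it is propyl in place of phenyl on a saturated ring carbon and the measured step was a 1.5-fold lower number from compound 2 to compound 1 (0.17 log units; within the scatter). Compound 4 `CCCC1Oc2c(Cl)cccc2N(O)C1=O` has not yet been measured; it stands to compound 3 as compound 1 stands to compound 2, the change being (propyl in place of phenyl on a saturated ring carbon). The surroundings of the change are the same in both pairs, so this is the same change rather than merely the same kind.

The step from compound 3 to compound 4 is expected to be a 1.5-fold lower number from compound 3 to compound 4 (0.16 log units; within the scatter), small and within the scatter. This expectation rests on compound 2 and compound 1, where the same change gave a 1.5-fold lower number from compound 2 to compound 1 (0.17 log units; within the scatter). Compound 4 is therefore expected to give roughly 180000 nM in this assay, most likely somewhere between 90000 nM and 350000 nM.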

Compound 4, half-maximal inhibitory concentration: 393000 nM
Compound 4: the middle estimate sits 2.2-fold (0.34 log units) below what was measured; measured number outside the range, above it.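

In this assay, putting propyl in place of phenyl on the saturated ring carbon gives a 1.5-fold higher number from compound 3 to compound 4 (0.17 log units; within the scatter), so this measurement cannot tell the two compounds apart. Set beside the earlier pair, the new step agrees with it as closely as repeated measurements of this kind can show: the same change on two cores in this assay, a 1.5-fold lower number (0.17 log units; within the scatter) from compound 2 to compound 1 and a 1.5-fold higher number (0.17 log units; within the scatter) from compound 3 to compound 4, 2.2-fold (0.34 log units) apart, within the scatter of two such steps. This shows that in both pairs the change from phenyl to propyl stays within the scatter, and that the two cores give no measurable sign of handling the change differently; it does not show that the steps truly point in opposite directions, and two pairs cannot show that the same would hold on any further core.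

Phenyl and propyl are the only two groups shown on this ring carbon, so it remains open how a small methyl group, a longer chain such as hexyl, or a chain ending in an amine or a carboxylic acid would read on either core. All the compounds shown also keep the hydroxy group on the ring atom that bears it, which leaves open what a methoxy group in its place would do to the number.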